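Swapping Chloro for Carbamoyl on the Aromatic Ring

The source may report more compounds than this note shows. Statements on the series, on what has been measured and on what is new or still open speak of the compounds shown alone.

Going by the values given here, compound 3 `O=C(CCCCCc1ccc(Cl)cc1)N1CCOC1=O` was tested in an assay on HEK293 cells for inhibition of N-acylethanolamine-hydrolyzing acid amidase (Rattus norvegicus), read by LC-MS, with a stated time of 30 min (on this read-out lower numbers stand for stronger inhibition and higher numbers for weaker inhibition), and gives 4600 nM, the highest of the two numbers measured so far. Compound 1 `O=C(CCCCCc1ccc(O)c(F)c1)N1CCOC1=O` gives 160 nM in this assay, a markedly lower number. Compound 2 `Nc1cccc(CCCCCC(=O)N2CCOC2=O)c1` gives only a limit of the assay in this assay, > 20000 nM, and not a number; it is one of the limit of > 20000 nM in this assay, at which 1 of the 3 values shown sits. The step to be followed leads from compound 3 to compound 4 `NC(=O)c1ccc(CCCCCC(=O)N2CCOC2=O)cc1`, which has not yet been measured in this assay. The change is carbamoyl in place of chloro on an aromatic carbon. Among the compounds with values here, with no measured step of this kind to lean on, the expected change is a 1.3-fold higher number from compound 3 to compound 4 (0.12 log units; within the scatter), a modest move toward weaker inhibition. Compound 4 is therefore estimated at 6000 nM, within a range of 1000 nM to 30000 nM.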

Compound 4, half-maximal inhibitory concentration: > 20000 nM
Compound 4 ended at the assay's limit; the forecaster's own chance of this, stated with the estimate: 30%; at least 3.3-fold (0.52 log units) between middle value and limit.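

Going by these compounds alone, the swap of chloro for carbamoyl on this aromatic carbon, para to a large group, gives the first measured step: an at least 4.3-fold higher number from compound 3 to compound 4 (0.63 log units; beyond the scatter), a move toward weaker inhibition. So this position is sensitive to the group it carries, at least for this change. The reading for compound 4 is a limit of the assay and not a number, so the full size of the step cannot be read: the limit of > 20000 nM in this assay, at which 2 of the 4 values shown sit.

As far as these compounds go, whether methoxy or a nitrile on this carbon would read closer to chloro or to carbamoyl remains open. Also open, from the compounds shown here alone, is whether a methyl group would keep the inhibition seen with chloro.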